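Moving the halogen on the benzoyl ring of compound 2

The compounds below may be only part of what the source reports. "The series", "measured", "known", "first", "only" and "open" are said of these compounds alone.

Of the compounds shown here, two have been measured so far. Compound 1 `Cc1ccc(OCC(=O)NNC(=O)c2cc3ccccc3oc2=O)c(C(=O)c2cccc(Cl)c2)c1` gives 64900 nM in a functional assay on Ehrlich cells (Mus musculus) for cytotoxicity, read by MTT assay, with a stated time of 48 h; a higher number here means a weaker inhibitor, a lower number a stronger inhibitor. Among the measured compounds shown here, compound 2 `Cc1ccc(OCC(=O)NNC(=O)c2cc3ccccc3oc2=O)c(C(=O)c2cccc(Br)c2)c1` gives 66400 nM in this assay, the higher of the two numbers, though the only step available, a 1.0-fold higher number from compound 1 to compound 2 (0.01 log units; within the scatter), is within the scatter, so the two compounds cannot be told apart on these data.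

Compound 3 `Cc1ccc(OCC(=O)NNC(=O)c2cc3ccccc3oc2=O)c(C(=O)c2ccc(F)cc2)c1` has not yet been measured. It differs from compound 2 in one place: 4-fluorophenyl in place of 3-bromophenyl on a carbonyl carbon. For the measured compounds named here, the sole measured step, from compound 1 to compound 2, concerns the same benzoyl ring and shows that swapping one halogen for another there left the number unchanged within the scatter. Going by the values given here, that step is the only guide; no measured pair shows what moving the halogen to a different position on this ring does. On that basis the step of a 1.0-fold lower number from compound 2 to compound 3 (0.01 log units; within the scatter) is expected to lie within the scatter as well, with no clear direction. Compound 3 is therefore estimated to give 65000 nM in this assay, most likely between 30000 nM and 140000 nM.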

Compound 3, half-maximal inhibitory concentration: 39700 nM
The estimate for compound 3 lay 1.6-fold (0.21 log units) above the measured number, within the range that was stated.
By their numbers in this assay, from the lowest: compounds 3, 1 and 2 (each within the scatter of the next).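

Among the compounds shown here, compound 3 is the first compound in which both the halogen and its place on the ring change at once, and in this assay neither step it adds separates it from the earlier compounds: the change from 3-bromophenyl to 4-fluorophenyl gives a 1.7-fold lower number from compound 2 to compound 3 (0.22 log units; within the scatter), and the change from 3-chlorophenyl to 4-fluorophenyl gives a 1.6-fold lower number from compound 1 to compound 3 (0.21 log units; within the scatter). The earlier pair covered only an exchange of one halogen for another, whereas these steps show that this combined change on the carbonyl carbon also stays within the scatter, so all three compounds remain indistinguishable on these data. Nothing available here explains these steps.

Since halogen and ring place change together in these steps, their separate contributions stay unresolved, and a 3-fluorophenyl or a 4-bromophenyl group would be needed to tell them apart. Going by these compounds, it also remains open whether a group other than a halogen on this ring, such as a methoxy group, an amine or a carboxylic acid, or an unsubstituted phenyl ring, would give a step beyond the scatter.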